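The source may hold more compounds than are shown below. What is called first, only, known or untested is meant among the compounds shown, and "the series" means these compounds.

The study concerns compounds built on a shared core and tested in an assay on isolated protein (Mus musculus) for inhibition of IL15-IL15 receptor (Homo sapiens), read by resazurin assay, with stated times of 30 min and 2.5 days; on this read-out higher numbers stand for weaker inhibition and lower numbers for stronger inhibition. Compound 1 `CCCOc1ccc(NC(=O)CSc2nnc(Cc3nn(C)c(=O)c4ccccc34)n2C)cc1` reaches only a limit of the assay, where compound 1 gives > 30000 nM. Going by the values given here, compound 2 `CC(C)COc1ccc(NC(=O)CCCCCCCSc2nnc(Cc3nn(C)c(=O)c4ccccc34)n2C)cc1` carries the one measured number: in this assay compound 2 gives 4800 nM. The other value shown, that of compound 1, is a limit, as the limit of > 30000 nM in this assay, at which 1 of the 2 values shown sits, records. Compound 3 `Cc1ccc(NC(=O)CCCCCCCSc2nnc(Cc3nn(C)c(=O)c4ccccc34)n2C)c(Cl)c1` has not yet been measured. It differs from compound 2 by one change: 2-chloro-4-methylphenyl in place of 4-(isobutoxy)phenyl on an amide-type nitrogen. Among the compounds with values here, no measured pair isolates this change, so the expectation for compound 3 rests on compound 2 alone. The step is expected to be modest, within the usual scatter or leaning towards weaker inhibition, as a 1.3-fold higher number from compound 2 to compound 3 (0.10 log units; within the scatter) states. Compound 3 is thus expected to give about 6000 nM in this assay, with a likely range from 1500 nM to 30000 nM.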

Compound 3, half-maximal inhibitory concentration: 2300 nM
Compound 3: the middle estimate sits 2.6-fold (0.42 log units) above what was measured, and the stated range covers the measured number.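

In this assay, 2-chloro-4-methylphenyl in place of 4-(isobutoxy)phenyl on the amide-type nitrogen gives a 2.1-fold lower number from compound 2 to compound 3 (0.32 log units; beyond the scatter), a modest gain in inhibition. This shows that the aryl group at this place can be exchanged without loss: the oxygen of the leaving group, its one hydrogen-bond acceptor, is not needed here, and the entering group, with fewer heavy atoms, serves at least as well. No measured property shown here accounts for the step.

Going by these compounds, the chlorine and the methyl enter together, so their separate shares remain open, and plain phenyl, 4-chlorophenyl or 4-methylphenyl would be needed to tell them apart. Also open, on these data alone, is whether a shorter or longer chain, or an amine or carboxylic acid on the aryl ring, would shift the number further.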